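Aryl substituent changes on the hydrazone series

This account rests on a few compounds, and the source may have more. Where it says the series, first, only, none or still open, it means among the compounds named here.

In a functional assay on BGC-823 cells (Homo sapiens) for cytotoxicity, read by MTT assay, with a stated time of 48 h (on this read-out higher numbers stand for weaker inhibition and lower numbers for stronger inhibition), compound 1 `O=C(CSc1nnc(-c2ccncc2)o1)N/N=C/c1ccc(F)cc1` gives 17800 nM, compound 2 `Cc1ccc(/C=N/NC(=O)CSc2nnc(-c3ccncc3)o2)cc1` gives 21800 nM, and compound 3 `O=C(CSc1nnc(-c2ccncc2)o1)N/N=C/c1ccccc1F` gives 24000 nM. Compound 3 carries the highest number of the three, but every separation is within the scatter: a 1.3-fold higher number from compound 1 to compound 3 (0.13 log units; within the scatter), a 1.1-fold higher number from compound 2 to compound 3 (0.04 log units; within the scatter), and likewise a 1.2-fold higher number from compound 1 to compound 2 (0.09 log units; within the scatter). Compound 4 `O=C(CSc1nnc(-c2ccncc2)o1)N/N=C/c1ccccc1[N+](=O)[O-]` differs from compound 3 in that (nitro in place of fluoro on an aromatic carbon). Within the data shown here, no measured step exchanges fluoro for nitro; the three changes to the aryl ring that were measured all left this assay within the scatter, so the expected step is no change at the digits printed from compound 3 to compound 4 (within the scatter), that is, no movement beyond the scatter in either direction. Compound 4 is therefore estimated at 24000 nM, with a range from 10000 nM to 55000 nM.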

Compound 4, half-maximal inhibitory concentration: 41600 nM
For compound 4 the middle estimate is 1.7-fold (0.24 log units) below the measured one; the range from low to high includes it.
By their numbers in this assay, from the lowest: compounds 1, 2, 3 and 4 (each within the scatter of the next, the first and the last beyond it).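

In this assay, nitro in place of fluoro on an aromatic carbon ortho to a large group stays inside the usual spread, with a 1.7-fold higher number from compound 3 to compound 4 (0.24 log units; within the scatter), and 2-nitrophenyl in place of 4-methylphenyl does too, with a 1.9-fold higher number from compound 2 to compound 4 (0.28 log units; within the scatter). Only 2-nitrophenyl in place of 4-fluorophenyl gives the series a separation beyond the scatter, modest in size, with a 2.3-fold higher number from compound 1 to compound 4 (0.37 log units; beyond the scatter). Nothing available explains this separation. Going by these compounds, the effect of an amine or a carboxylic acid on this aromatic carbon remains open, as does whether this separation persists with changes to the shared core.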